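The source may report more compounds than this note shows. Statements on the series, on what has been measured and on what is new or still open speak of the compounds shown alone.

In a physicochemical assay for lipophilicity, read by HPLC, measured as octanol-water partition (a higher number here means a more lipophilic compound, a lower number a more polar compound), compound 1 `N#Cc1c(-c2ccco2)[n+]([O-])c2ccc(C3OCCO3)cc2[n+]1[O-]` reads 2 and compound 2 `O=C(N/N=C/c1ccc2no[n+]([O-])c2c1)c1ccccc1` reads 2.2 on the scale. Among the compounds with values here, compound 3 `O=C(N/N=C/c1ccc2no[n+]([O-])c2c1)c1ccc([N+](=O)[O-])cc1` reads 0.9 as the lowest of the three numbers so far. Compound 4 `CC(C)(C)c1ccc(C(=O)N/N=C/c2ccc3no[n+]([O-])c3c2)cc1` has no number yet. The change from compound 3 is counted as tert-butyl in place of nitro on an aromatic carbon and in words it is tert-butyl in place of nitro on an aromatic carbon, para to a large group.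

Within the data shown here, one measured step bears on this. Nitro in place of hydrogen on an aromatic carbon gave a number 1.30 log units lower from compound 2 to compound 3 (beyond the scatter) in this assay and that step is large. Taking nitro away should undo a step of about that size. Among the measured compounds shown here, no measured step shows what tert-butyl does here, so its share is a judgement, and the whole step is expected to be upward, beyond the scatter and larger than the measured one. The expected result is a number 2.50 log units higher from compound 3 to compound 4 (beyond the scatter) as an estimate. Compound 4 is expected at 3.4 within a range of 2.7 to 4.1 on that scale.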

Compound 4, partition coefficient: 3.8
Beside the measured number, compound 4's estimate is 0.40 log units below it; the range from low to high includes it.
By their numbers in this assay, from the lowest: compound 3; then compounds 1 and 2 (each within the scatter of the next); then compound 4.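

Tert-butyl in place of hydrogen on this aromatic carbon gives a number 1.60 log units higher from compound 2 to compound 4 (beyond the scatter) in this assay and so supplies the first measured upward step at this position, where only a downward step with nitro had been seen. Exchanging one group for the other gives a number 2.90 log units higher from compound 3 to compound 4 (beyond the scatter) and this is the widest step among these compounds, with the hydrogen compound lying between the nitro and tert-butyl compounds on the scale. Nothing measured here explains why these groups move the number as they do.

Only hydrogen, nitro and tert-butyl are shown at this place, so the positions of an amine, a carboxylic acid or a longer chain on this scale remain open. Also open, going by these compounds, is whether tert-butyl would produce a similar step on a different core, such as the core of compound 1.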